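The compounds below may be only part of what the source reports. "The series", "measured", "known", "first", "only" and "open" are said of these compounds alone.

Compound 1 `CC(C)=CCC/C(C)=C/CC1Cc2c(OCCCNS(=O)(=O)c3ccc(Br)cc3)cc(=O)n(CCCO)c2CC1(C)C` gives 0% in a functional assay on PANC-1 cells (Homo sapiens) for inhibition, read by MTT assay, with a stated time of 24 h, tested at 10 uM; on this read-out lower numbers stand for less inhibition and higher numbers for more inhibition at the one concentration tested (going by the name of the read-out); compound 2 `COc1ccc(C(=O)NCCCOc2cc(=O)n(CCCO)c3c2CC(C/C=C(\C)CCC=C(C)C)C(C)(C)C3)cc1` gives 14.1%; compound 3 `COc1ccc(OCCCOc2cc(=O)n(CCCO)c3c2CC(C/C=C(\C)CCC=C(C)C)C(C)(C)C3)cc1` gives 0%.

Compound 3 stands level with compound 1, the two lying together at the bottom of the three numbers; the step of no change at the digits printed from compound 1 to compound 3 (within the scatter) separates them by nothing, while a number 14.1 percentage points lower from compound 2 to compound 3 (beyond the scatter) sets compound 2 apart.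

Compound 4 `CC(C)=CCC/C(C)=C/CC1Cc2c(OC(=O)Nc3ccc(Cl)cc3)cc(=O)n(CCCO)c2CC1(C)C` carries the change ((4-chlorophenyl)carbamoyl in place of 3-(4-methoxyphenoxy)propyl on an oxygen on an aromatic ring). Among the compounds with values here, the measured steps of a number 14.1 percentage points higher from compound 1 to compound 2 (beyond the scatter) and a number 14.1 percentage points lower from compound 2 to compound 3 (beyond the scatter) concern only the end of the propyl chain and say nothing of removing that chain altogether, so no step bears directly on this change. With compound 3 at 0%, compound 4 is expected to move by a number 5 percentage points higher from compound 3 to compound 4 (within the scatter), within the scatter, and its value is estimated at 5%, between 0% and 25%.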

Compound 4, a percentage reported as inhibition, at one concentration (the size of the read-out at that concentration, not a potency): 4.3%
The estimate for compound 4 lay 0.7 percentage points above the measured number; the measured number falls inside the stated range.
By their numbers in this assay, from the lowest: compounds 1, 3, 4 and 2 (each within the scatter of the next, the first and the last beyond it).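

In this assay the swap of 3-(4-methoxyphenoxy)propyl for (4-chlorophenyl)carbamoyl on this oxygen gives a number 4.3 percentage points higher from compound 3 to compound 4 (within the scatter) and so shows that the read-out does not move beyond the scatter when the whole propyl chain leaves this position. No measurement offered here explains this result. Because the link and the ring substituent change together, the compounds shown do not separate their contributions. They also leave open how a longer chain or a terminal amine on this oxygen would read.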